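From a Methoxy Alcohol Chain to a Carboxy Group

The source may report more compounds than this note shows. Statements on the series, on what has been measured and on what is new or still open speak of the compounds shown alone.

In an ADME assay on S9 fraction from liver (Rattus norvegicus) for metabolic stability, read by LC-MS, using NADPH, with a stated time of 60 min, tested at 10 uM (a lower number here means that less of the compound is left, a higher number that more of the compound is left), compound 1 `C[C@@H](O)Cc1cc(-c2ccnc3[nH]nc(C(F)(F)F)c23)cc(C2(C#N)CC2)c1` gives 42%, compound 2 `N#CC1(c2cc(CC(O)C(F)(F)F)cc(-c3ccnc4[nH]nc(C(F)(F)F)c34)c2)CC1` gives 71% and compound 3 `COCC(O)Cc1cc(-c2ccnc3[nH]nc(C(F)(F)F)c23)cc(C2(C#N)CC2)c1` gives 51%. Two steps place the last of these: a number 9 percentage points higher from compound 1 to compound 3 (within the scatter), and a number 20 percentage points lower from compound 2 to compound 3 (beyond the scatter). Compound 3 thus sits with compound 1 and apart from compound 2.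

Compound 4 `N#CC1(c2cc(CC(=O)O)cc(-c3ccnc4[nH]nc(C(F)(F)F)c34)c2)CC1` has not yet been measured. Its difference from compound 3 is carboxy in place of 1-hydroxy-2-methoxyethyl on a saturated chain carbon bound to an aromatic carbon.

Within the data shown here, no measured step introduces a carboxy group, so the evidence is indirect. All three measured steps change the group at this same place, and they show that such a change can leave the number within the scatter or shift it by a modest amount. The clearest shift is a number 29 percentage points higher from compound 1 to compound 2 (beyond the scatter). Taking that upward step as the guide, a rise of similar modest size is expected, though with wide uncertainty. The expected step is a number 21 percentage points higher from compound 3 to compound 4 (beyond the scatter). For compound 4 the estimated value is 72%, with an expected range from 52% to 90%.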

Compound 4, percent of the compound remaining: 95%
Estimate against measurement, compound 4: 23 percentage points below; the measured number lies above the stated range.
By their numbers in this assay, from the lowest: compounds 1 and 3 (each within the scatter of the next); then compound 2; then compound 4.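

Among these compounds, on the saturated chain carbon bound to an aromatic carbon, the hydroxy-bearing groups had so far given at most modest steps in this assay, and carboxy is the first group there to give large ones (a number 44 percentage points higher from compound 3 to compound 4 (beyond the scatter); a number 53 percentage points higher from compound 1 to compound 4 (beyond the scatter)). It also goes past 2,2,2-trifluoro-1-hydroxyethyl, the best of the hydroxy-bearing groups (a number 24 percentage points higher from compound 2 to compound 4 (beyond the scatter)), so compound 4 stands highest of the four, and among these compounds the highest number comes without a hydroxy group on the chain. Nothing measured here accounts for this rise, so the result stands as an observation without an explanation.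

The compounds shown do not tell whether the rise comes from the carboxy group itself or from the change from 2-hydroxy-3-methoxypropyl to the shorter carboxymethyl. As far as these compounds go, it also remains open whether a carboxylic acid on a longer chain, a primary amide or an amine at this place would give a number in the range of compound 4 or one closer to those of the hydroxy-bearing chains.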